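The compounds below may be only part of what the source reports. "The series", "measured", "known", "first", "only" and "open" are said of these compounds alone.

Measured in a functional assay on MCF7 cells (Homo sapiens) for cytotoxicity, read by CellTiter-Blue, with a stated time of 72 h; on this read-out higher numbers stand for weaker inhibition and lower numbers for stronger inhibition:
compound 1 `C/C=C(\C)[C@H]1OC(=O)[C@@H](C)NC(=O)[C@H]([C@@H](C)CC)NC(=O)CN(C)C(=O)[C@@H](Cc2ccccc2)N(C)C(=O)[C@H](C)NC(=O)[C@@H](CC(C)C)OC(=O)/C(C)=C/C[C@H](OCSC)[C@@H]1C`: 6.3 nM
compound 2 `C/C=C(\C)[C@H]1OC(=O)[C@@H](C)NC(=O)[C@H]([C@@H](C)CC)NC(=O)CN(C)C(=O)[C@@H](Cc2ccc(Cl)cc2)N(C)C(=O)[C@H](C)NC(=O)[C@@H](CC(C)C)OC(=O)/C(C)=C/C[C@H](O)[C@@H]1C`: 0.003 nM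

Compound 2 has the lower of the two numbers, and its gap to compound 1 lies beyond the scatter. Compound 3 `C/C=C(\C)[C@H]1OC(=O)[C@@H](C)NC(=O)[C@H]([C@@H](C)CC)NC(=O)CN(C)C(=O)[C@@H](Cc2ccc(Cl)cc2)N(C)C(=O)[C@H](C)NC(=O)[C@@H](CC(C)C)OC(=O)/C(C)=C/C[C@H](OCSC)[C@@H]1C` follows from compound 2 through a single change: (methylsulfanyl)methyl in place of hydrogen on an oxygen on a saturated carbon. In words, (methylsulfanyl)methyl stands in place of hydrogen on an oxygen on a saturated carbon, so a hydroxy becomes (methylsulfanyl)methoxy. Among the measured compounds shown here, no measured pair shows this change alone, so its size is unknown. Compound 1 also carries (methylsulfanyl)methoxy and gives 6.3 nM, but it differs from compound 2 elsewhere too. A large move toward weaker inhibition in this assay, beyond the scatter, is therefore expected. The expected size is a 330-fold higher number from compound 2 to compound 3 (2.52 log units; beyond the scatter). For compound 3 the estimated value is 1 nM, with an expected range of 0.1 nM to 8 nM.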

Compound 3, half-maximal inhibitory concentration: 6.5 nM
Beside the measured number, compound 3's estimate is 6.5-fold (0.81 log units) below it, within the range that was stated.
By their numbers in this assay, from the lowest: compound 2; then compounds 1 and 3 (each within the scatter of the next).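

Replacing hydrogen with (methylsulfanyl)methyl on an oxygen on a saturated carbon now has a measured size in this assay (a 2200-fold higher number from compound 2 to compound 3 (3.34 log units; beyond the scatter)), with nothing else in the structure changed, so this hydroxy matters greatly to the number. Once (methylsulfanyl)methoxy is present, chloro in place of hydrogen on an aromatic carbon gives only a 1.0-fold higher number from compound 1 to compound 3 (0.01 log units; within the scatter), a step within the scatter, so no effect of chloro can be read in that setting. Nothing available explains either result.

The compounds shown do not reveal what chloro does when the free hydroxy is present, as none pairs with compound 2 by carrying hydrogen in place of that chloro. From the compounds shown here alone, it also remains open how a smaller methyl or an acetyl group on the same oxygen would compare with hydroxy and (methylsulfanyl)methoxy.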